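The compounds below may be only part of what the source reports. "The series", "measured", "known", "first", "only" and "open" are said of these compounds alone.

Four compounds share one core and differ only in the aromatic ring attached to a carbon with a double bond to nitrogen. Compound 1 `CN(C)CCn1cnnc1-c1cc(Oc2ccc(NC(=O)N/N=C/c3cccc(O)c3)cc2F)ccn1` carries a 3-hydroxyphenyl there. In a functional assay on U-87MG ATCC cells (Homo sapiens) for cytotoxicity, read by MTT assay, with a stated time of 72 h (a lower number here means a stronger inhibitor, a higher number a weaker inhibitor), compound 1 reaches only the limit > 100000 nM, which is a limit of the measurement and not a number. Compound 2 `CN(C)CCn1cnnc1-c1cc(Oc2ccc(NC(=O)N/N=C/c3ccc(O)c(Br)c3)cc2F)ccn1` carries a 3-bromo-4-hydroxyphenyl, and in this assay compound 2 gives 12400 nM. Compound 3 `COc1ccc(/C=N/NC(=O)Nc2ccc(Oc3ccnc(-c4nncn4CCN(C)C)c3)c(F)c2)cc1O` carries a 3-hydroxy-4-methoxyphenyl. In this assay compound 3 likewise reaches only the limit > 100000 nM, again a limit rather than a number. Compound 3 thus sits at the weak end of what is shown, sharing that limit with one other compound (the limit of > 100000 nM in this assay, at which 2 of the 3 values shown sit). Within the data shown here, the step of an at least 8.0-fold higher number from compound 2 to compound 3 (0.90 log units; beyond the scatter) is the only readable step that ends at compound 3, while the step that the two limits leave unreadable from compound 1 to compound 3 cannot be read; the step of an at least 8.0-fold lower number from compound 1 to compound 2 (0.90 log units; beyond the scatter) shows that the single ring bearing a halogen is the one that yields a number. Compound 4 `CN(C)CCn1cnnc1-c1cc(Oc2ccc(NC(=O)N/N=C/c3c(Cl)cccc3Cl)cc2F)ccn1` brings the change (2,6-dichlorophenyl in place of 3-hydroxy-4-methoxyphenyl on a carbon with a double bond to nitrogen). Among the measured compounds shown here, no measured pair tests two chlorines, so the expectation rests on compound 2 alone. A modest drop in number is expected, an at least 3.3-fold lower number from compound 3 to compound 4 (0.52 log units; beyond the scatter), although another limit remains quite possible. Compound 4 is therefore estimated at 30000 nM, between 5000 nM and 100000 nM.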

Compound 4, half-maximal inhibitory concentration: > 100000 nM
Compound 4: only a limit was reported; the forecaster's own chance of this, stated with the estimate: 45%; middle value at least 3.3-fold (0.52 log units) away from the limit.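

In this assay compound 4 also stops at a limit, > 100000 nM, and this is a limit of the assay rather than a number. The step of an at least 8.0-fold higher number from compound 2 to compound 4 (0.90 log units; beyond the scatter) shows that a halogen on this ring does not by itself yield a number: the 2,6-dichlorophenyl carries two chlorines and still falls short of the 3-bromo-4-hydroxyphenyl, the only ring here that gives a measured value. The steps from compound 1 and from compound 3 to compound 4 cannot be read, since both ends of each are limits, so the three rings without a number cannot be ranked against one another: the limit of > 100000 nM in this assay, at which 3 of the 4 values shown sit.

The compounds shown leave open whether the bromine alone or the bromine together with the hydroxy group on the same ring gives compound 2 its number, a question that a 3-bromophenyl or a 4-hydroxyphenyl would address. They also leave open what a ring bearing a dimethylamino group or a carboxylic acid would give on this carbon with a double bond to nitrogen.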